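Adding thiophen-2-yl to compound 3

The source may report more compounds than this note shows. Statements on the series, on what has been measured and on what is new or still open speak of the compounds shown alone.

In a functional assay on MOLT-4 cells (Homo sapiens) for cytotoxicity, read by CCK-8 assay, with a stated time of 24 h (a lower number here means a stronger inhibitor, a higher number a weaker inhibitor), compound 3 `C=CC(=O)N1C(=O)CCSc2ccccc21` gives 565000 nM. Compound 1 `C=CC(=O)N1C(=O)CC(C)Sc2ccccc21`, which carries a methyl group on the same saturated ring carbon, gives 730000 nM, and the comparison shows a 1.3-fold lower number from compound 1 to compound 3 (0.11 log units; within the scatter). Compound 2 `C=CC(=O)N1C(=O)CC(c2ccc(Cl)cc2)Sc2ccccc21`, which carries 4-chlorophenyl there, gives 82400 nM, so compound 3 sits well above it on this scale.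

Compound 4 `C=CC(=O)N1C(=O)CC(c2cccs2)Sc2ccccc21` differs from compound 3 by thiophen-2-yl in place of hydrogen on a saturated ring carbon, with thiophen-2-yl in place of hydrogen on a saturated ring carbon. Within the data shown here, the closest guide is compound 2, the only measured compound with an aromatic ring at that carbon, which gives a 6.9-fold higher number from compound 2 to compound 3 (0.84 log units; beyond the scatter). Compound 1 adds an 8.9-fold lower number from compound 1 to compound 2 (0.95 log units; beyond the scatter). Among the measured compounds shown here, these few compounds offer thin evidence, and no thiophen-2-yl compound has been measured, so a similar but slightly smaller drop seems reasonable. The expected change is a 4.7-fold lower number from compound 3 to compound 4 (0.67 log units; beyond the scatter). For compound 4, the estimated value is 120000 nM, with an expected range from 50000 nM to 320000 nM.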

Compound 4, half-maximal inhibitory concentration: 557000 nM
Estimate against measurement, compound 4: 4.6-fold (0.67 log units) below; the whole stated range lies below it.
By their numbers in this assay, from the lowest: compound 2; then compounds 4, 3 and 1 (each within the scatter of the next).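

On this saturated ring carbon, an aromatic ring alone does not lower the number in this assay: thiophen-2-yl in place of hydrogen gives a 1.0-fold lower number from compound 3 to compound 4 (0.01 log units; within the scatter) and thiophen-2-yl in place of methyl gives a 1.3-fold lower number from compound 1 to compound 4 (0.12 log units; within the scatter). Among the compounds shown, only 4-chlorophenyl stands apart at this carbon, and exchanging it for thiophen-2-yl gives a 6.8-fold higher number from compound 2 to compound 4 (0.83 log units; beyond the scatter). Nothing available explains why these two aromatic groups differ.

From the compounds shown here alone, it remains open whether plain phenyl, which lacks the chlorine, would fall with 4-chlorophenyl or with thiophen-2-yl, and whether 4-methoxyphenyl or 3-chlorophenyl would keep the lower number. How an amine or a carboxylic acid at this carbon would behave also remains an open question.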